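This account rests on a few compounds, and the source may have more. Where it says the series, first, only, none or still open, it means among the compounds named here.

Series notes, step from compound 3 to compound 4.

Three members of the series have been run in a functional assay on Huh-7 cells (Homo sapiens) for cytotoxicity, with a stated time of 48 h; a higher number here means a weaker inhibitor, a lower number a stronger inhibitor. Compound 1 `N#Cc1ccc(-c2cc(COC(Cc3cn(C4CCN(Cc5ccc([N+](=O)[O-])cc5)CC4)nn3)c3ccc(Br)cc3)on2)cc1` gives 5000 nM. Compound 2 `O=[N+]([O-])c1ccc(CN2CCC(n3cc(CC(OCc4cc(-c5cccc(Br)c5)no4)c4ccc(Br)cc4)nn3)CC2)cc1` gives 3000 nM. Compound 3 `N#Cc1cccc(-c2cc(COC(Cc3cn(C4CCN(Cc5ccc([N+](=O)[O-])cc5)CC4)nn3)c3ccc(Br)cc3)on2)c1` gives 3000 nM. On these numbers compound 3 sits level with compound 2 at the digits printed, the two of them giving the lowest numbers of the three, while compound 1 sits furthest off. The whole spread is small: a 1.7-fold lower number from compound 1 to compound 2 (0.22 log units; within the scatter) and a 1.7-fold lower number from compound 1 to compound 3 (0.22 log units; within the scatter) are both within the scatter, and no change at the digits printed from compound 2 to compound 3 (within the scatter) is no change at all.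

Compound 4 `O=[N+]([O-])c1ccc(CN2CCC(n3cc(CC(OCc4cc(-c5ccccc5Br)no4)c4ccc(Br)cc4)nn3)CC2)cc1` is the next variation on the same pendant ring. The change is 2-bromophenyl in place of 3-cyanophenyl on an aromatic carbon.

The measured steps that bear on it are no change at the digits printed from compound 2 to compound 3 (within the scatter), where swapping cyano for bromo left the number unchanged, and a 1.7-fold lower number from compound 1 to compound 2 (0.22 log units; within the scatter), where moving from a 4-cyanophenyl to a 3-bromophenyl moved the number only within the scatter. Both point the same way: exchanging one substituted phenyl for another at this ring position has so far done nothing beyond the scatter in this assay. On that basis no step beyond the scatter is expected, in either direction, for compound 4; the expected step is a 1.2-fold higher number from compound 3 to compound 4 (0.07 log units; within the scatter). Compound 4 is therefore estimated at 3500 nM, with a range from 1500 nM to 8000 nM.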

Compound 4, half-maximal inhibitory concentration: > 25000 nM
Compound 4: no number, only a limit; the forecaster's own chance of this, stated with the estimate: 10%; middle value at least 7.1-fold (0.85 log units) from the limit.
By their numbers in this assay, from the lowest: compounds 2, 3 and 1 (each within the scatter of the next). At a limit, above all of these: compound 4.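

In this assay compound 4 stands at a limit of the assay and not at a number: the limit of > 25000 nM in this assay, at which 1 of the 4 values shown sits. Among these compounds, with 2-bromophenyl in place of 3-bromophenyl as the only change, the series shows an at least 8.3-fold higher number from compound 2 to compound 4 (0.92 log units; beyond the scatter), so the place of the bromine on this phenyl matters here, which the earlier exchanges, such as no change at the digits printed from compound 2 to compound 3 (within the scatter) and a 1.7-fold lower number from compound 1 to compound 2 (0.22 log units; within the scatter), gave no sign of. The same direction appears against both cyanophenyl compounds, with an at least 8.3-fold higher number from compound 3 to compound 4 (0.92 log units; beyond the scatter) and an at least 5.0-fold higher number from compound 1 to compound 4 (0.69 log units; beyond the scatter), so this aromatic carbon of the five-membered ring is not indifferent to every substituted phenyl, and among the four compounds shown only the 2-bromophenyl stands beyond the scatter from the others.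

On these data alone, the true size of these steps stays open, since each rests on a limit, and a single compound cannot separate an effect of bromine from an effect of any group at that place on the phenyl. A 2-methylphenyl, a 2-chlorophenyl or a 2-cyanophenyl, set against an unsubstituted phenyl, would be the comparison that tells these apart.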